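Para substituent on the phenyl of the piperidine acetamide series

A few compounds are considered here, and "the series" means these few. Any claim that something is new, unique, unknown or untested is made for them only; others in the source may bear on it.

Measured compounds:
compound 1 `Cc1cccc(NC(=O)CN2CCC(c3ccc(Cl)cc3)CC2)c1`: 70200 nM
compound 2 `O=C(CN1CCN(c2ccccn2)CC1)Nc1cccnc1`: 86500 nM
compound 3 `Cc1cccc(NC(=O)CN2CCC(c3ccccc3)CC2)c1`: 2 nM

In a functional assay on cells for antagonist activity at D(4) dopamine receptor (Homo sapiens), read by TR-FRET and cAMP accumulation, with a stated time of 30 min (on this read-out lower numbers stand for stronger inhibition and higher numbers for weaker inhibition), compound 3 gives the lowest of the three numbers. Its nearest neighbour is compound 1, which differs only by chloro on an aromatic carbon, and the gap between them is a 35000-fold lower number from compound 1 to compound 3 (4.55 log units; beyond the scatter). Compound 2, with a different core, gives a number further away still.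

The next compound, compound 4 `Cc1ccc(C2CCN(CC(=O)Nc3cccc(C)c3)CC2)cc1`, carries methyl in place of hydrogen on an aromatic carbon. Within the data shown here, the one measured step that bears on this change is the one from compound 1 to compound 3, since it also concerns a single small group on an aromatic carbon of the same phenyl: that step was very large, a 35000-fold lower number from compound 1 to compound 3 (4.55 log units; beyond the scatter). Among the measured compounds shown here, whether a methyl behaves like a chloro at this place cannot be read from two compounds, but the only evidence available says that filling this aromatic carbon costs a great deal in this assay. An increase in the number is therefore expected, likely large but with wide uncertainty.

The step from compound 3 to compound 4 is estimated as a 1500-fold higher number from compound 3 to compound 4 (3.18 log units; beyond the scatter) in this assay. For compound 4 the expected value in this assay is 3000 nM, with a range from 50 nM to 60000 nM.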

Compound 4, half-maximal inhibitory concentration: 3060 nM
Estimate against measurement, compound 4: 1.0-fold (0.01 log units) below; the range from low to high includes it.
By their numbers in this assay, from the lowest: compound 3; then compound 4; then compounds 1 and 2 (each within the scatter of the next).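

In this assay, the change from phenyl to 4-methylphenyl gives a 1500-fold higher number from compound 3 to compound 4 (3.18 log units; beyond the scatter), so the loss seen with chloro on this aromatic carbon, para to a large group, is not confined to chloro. Among the three compounds that differ at this place, compound 3, with hydrogen, gives the lowest number, and both compound 1 and compound 4 lie far from it. The two groups are not interchangeable, however: methyl in place of chloro gives a 23-fold lower number from compound 1 to compound 4 (1.36 log units; beyond the scatter), so the identity of the group matters here as well as whether hydrogen has been replaced. Nothing available accounts for either step or for the gap between methyl and chloro.

On these data alone, with only chloro and methyl on this carbon, it remains open whether every replacement of hydrogen brings a loss of this size, and fluoro, a hydroxyl group, an amine or a carboxylic acid at the same place would test that. Also open, as far as these compounds go, are whether a longer chain such as ethyl would lie closer to compound 4 or further from it, and whether methyl or chloro on another carbon of this phenyl would give steps of similar size.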